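Aryl ether variation at the pyrazole oxygen: compound 4

The compounds below may be only part of what the source reports. "The series", "measured", "known", "first", "only" and "open" are said of these compounds alone.

Three measured members of the series share one core and differ only in the aryl group on an oxygen on an aromatic ring. Compound 1 `Cc1nn(C)c(Oc2ccc(F)c(F)c2)c1/C=N\CCCCCCOc1cc2oc(=O)cc(C)c2cc1Cl` gives in a functional assay on SMMC-7721 cells (Homo sapiens) for antiproliferative activity, read by MTT assay, with a stated time of 72 h (a higher number here means a weaker inhibitor, a lower number a stronger inhibitor), only a limit, > 25000 nM, with no number (the limit of > 25000 nM in this assay, at which 1 of the 3 values shown sits). Compound 2 `Cc1nn(C)c(Oc2ccccc2Br)c1/C=N\CCCCCCOc1cc2oc(=O)cc(C)c2cc1Cl` gives 19700 nM in this assay, and compound 3 `Cc1nn(C)c(Oc2ccc(Br)cc2)c1/C=N\CCCCCCOc1cc2oc(=O)cc(C)c2cc1Cl` gives 3090 nM, the lowest number among the two numbers available. The steps of an at least 8.0-fold lower number from compound 1 to compound 3 (0.90 log units; beyond the scatter) and a 6.4-fold lower number from compound 2 to compound 3 (0.80 log units; beyond the scatter) both point the same way, and an at least 1.2-fold lower number from compound 1 to compound 2 (0.10 log units; that floor lies within the scatter) lies within the scatter.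

Compound 4 `Cc1ccccc1Oc1c(/C=N\CCCCCCOc2cc3oc(=O)cc(C)c3cc2Cl)c(C)nn1C` has not yet been tested. The change is 2-methylphenyl in place of 4-bromophenyl on an oxygen on an aromatic ring. Among the compounds with values here, the one measured step that bears on it is the move from 2-bromophenyl to 4-bromophenyl, a 6.4-fold lower number from compound 2 to compound 3 (0.80 log units; beyond the scatter), in which the substituent leaves the 2-position of the ring; compound 4 returns a substituent to that position, although a methyl rather than a bromine. The expectation is therefore a higher number in this assay for compound 4, a step of about a 3.9-fold higher number from compound 3 to compound 4 (0.59 log units; beyond the scatter). Compound 4 is estimated at 12000 nM, within 4000 nM to 30000 nM.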

Compound 4, half-maximal inhibitory concentration: 5120 nM
Beside the measured number, compound 4's estimate is 2.3-fold (0.37 log units) above it, and the stated range covers the measured number.
By their numbers in this assay, from the lowest: compounds 3 and 4 (each within the scatter of the next); then compound 2. At a limit, above all of these: compound 1.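

In this assay methyl in place of bromo on an aromatic carbon gives a 3.8-fold lower number from compound 2 to compound 4 (0.59 log units; beyond the scatter) and shows that a group on the ring at this place does not by itself bring a high number, since the outcome changes with the group carried. 2-Methylphenyl in place of 4-bromophenyl gives a 1.7-fold higher number from compound 3 to compound 4 (0.22 log units; within the scatter) so these two aryl groups cannot be ordered, and two different substitution patterns are now tied at the low end of the series. Against 3,4-difluorophenyl the step is an at least 4.8-fold lower number from compound 1 to compound 4 (0.68 log units; beyond the scatter) and this is only a floor, as the value for compound 1 is a limit: the limit of > 25000 nM in this assay, at which 1 of the 4 values shown sits.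

Open, as far as these compounds go, is how 4-methylphenyl or 2-methoxyphenyl would compare with compound 3 and compound 4. Also open, from the compounds shown here alone, is whether an amine or a carboxylic acid on this aryl ring would be tolerated.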